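The source may hold more compounds than are shown below. What is called first, only, known or untested is meant among the compounds shown, and "the series" means these compounds.

Working notes on the series. Compound 3 `CNc1ncnc2c1c(-c1cc3ccccc3o1)cn2[C@@H]1O[C@H](CO)[C@@H](O)[C@H]1O` carries 1-benzofuran-2-yl on the shared core, and in an ADME assay on MRC5 cells (Homo sapiens), read by MTT assay, with a stated time of 72 h (a higher number here means a weaker inhibitor, a lower number a stronger inhibitor), compound 3 gives 75300 nM. Compound 1 `CNc1ncnc2c1c(-c1ccccc1)cn2[C@@H]1O[C@H](CO)[C@@H](O)[C@H]1O` differs from it by phenyl in place of 1-benzofuran-2-yl on an aromatic carbon. In this assay compound 1 gives > 100000 nM, which is a limit of the assay and not a number. The step of an at least 1.3-fold higher number from compound 3 to compound 1 (0.12 log units; that floor lies within the scatter) is therefore only a floor. Compound 2 `O=c1[nH]cnc2c1c(-c1cc3ccccc3o1)cn2[C@@H]1O[C@H](CO)[C@@H](O)[C@H]1O` has a different core from compound 3; the difference between the two cores is not broken down here. In this assay compound 2 gives > 100000 nM, again a limit of the assay. Compound 4 `O=c1[nH]cnc2c1c(-c1ccccc1)cn2[C@@H]1O[C@H](CO)[C@@H](O)[C@H]1O`, not yet measured, differs from compound 2 by phenyl in place of 1-benzofuran-2-yl on an aromatic carbon, the same change as from compound 3 to compound 1. Compound 4 is expected to stay at the limit, a step that the limit leaves unreadable from compound 2 to compound 4, because compound 2 already stands at the limit of > 100000 nM in this assay, at which 2 of the 3 values shown sit, and the measured step gave no lower number. The estimate for compound 4 is 150000 nM, expected within 80000 nM to 400000 nM.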

Compound 4, half-maximal inhibitory concentration: > 100000 nM
Compound 4 was reported as a limit (the forecaster's own chance of this, stated with the estimate: 90%); the middle value is on the limit's open side.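

Among the compounds shown here, compound 2 and compound 4 are both reported only as limits in this assay, so no step between them can be read: the limit of > 100000 nM in this assay, at which 3 of the 4 values shown sit. The compounds shown leave open whether phenyl and 1-benzofuran-2-yl differ at all on this core.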